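The source may report more compounds than this note shows. Statements on the series, on what has been measured and on what is new or still open speak of the compounds shown alone.

Measured compounds:
compound 1, `CC(=O)c1ccc(C(=O)N[C@@H](C)Cn2ccc(-c3ccc(C#N)c(Cl)c3)n2)cc1`, 1400 nM
compound 2, `COc1ccc(C(=O)N[C@@H](C)Cn2ccc(-c3ccc(C#N)c(Cl)c3)n2)cc1`, 1540 nM
compound 3, `COC(=O)/C=C/C(=O)N[C@@H](C)Cn1ccc(-c2ccc(C#N)c(Cl)c2)n1`, 5230 nM

All three share one core and differ only in the group attached to the amide on the chain. In a functional assay on VCaP cells (Homo sapiens) for antiproliferative activity, read by CCK-8 assay, with a stated time of 6 days (on this read-out higher numbers stand for weaker inhibition and lower numbers for stronger inhibition), compound 3 gives the highest number of the three. The two steps toward it show how: a 3.7-fold higher number from compound 1 to compound 3 (0.57 log units; beyond the scatter) and a 3.4-fold higher number from compound 2 to compound 3 (0.53 log units; beyond the scatter), both modest, both beyond the scatter. Between compound 1 and compound 2 the change is small, a 1.1-fold higher number from compound 1 to compound 2 (0.04 log units; within the scatter), so the two aryl amides sit together and the unsaturated ester of compound 3 stands apart.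

Compound 4, `Cc1ccnc(N[C@@H](C)Cn2ccc(-c3ccc(C#N)c(Cl)c3)n2)n1`, is built from compound 3 by the change (4-methylpyrimidin-2-yl in place of (2-(methoxycarbonyl)ethenyl)carbonyl on an amine nitrogen). The amide carbonyl goes away entirely; an aromatic ring is attached straight to the nitrogen. Among the compounds with values here, no measured pair shows exactly this change. What the data do show is that an aromatic group on the carbonyl (compound 1, compound 2) gave lower numbers than the 2-(methoxycarbonyl)ethenyl group of compound 3, so bringing back an aromatic ring is expected to move the number down again, by a modest step, a 4.0-fold lower number from compound 3 to compound 4 (0.60 log units; beyond the scatter). Since the amide itself is lost, the uncertainty is wide. Compound 4 is therefore expected to reach about 1300 nM in this assay, within a range from 300 nM to 5500 nM.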

Compound 4, half-maximal inhibitory concentration: 850 nM
The estimate for compound 4 lay 1.5-fold (0.18 log units) above the measured number, within the range that was stated.
By their numbers in this assay, from the lowest: compounds 4, 1 and 2 (each within the scatter of the next); then compound 3.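

In this assay, putting 4-methylpyrimidin-2-yl in place of (2-(methoxycarbonyl)ethenyl)carbonyl on the amine nitrogen gives a 6.2-fold lower number from compound 3 to compound 4 (0.79 log units; beyond the scatter). The earlier compounds shown here all carried a carbonyl on this nitrogen, so they could not show that a compound without one can still reach the level of the aryl amides: compound 4, compound 1 and compound 2 lie within the scatter of one another in an unbroken run, and only compound 3 stands apart. Nothing measured here explains why the number falls with this change.

This single change removes the carbonyl and brings in an aromatic ring at the same time, so the compounds shown cannot say how much of the step belongs to each, and a 4-methylpyrimidine-2-carbonyl group on the same nitrogen would be needed to tell them apart. As far as these compounds go, the part played by the methyl also stays open, as does the reading of a plain pyrimidin-2-yl or a phenyl group attached directly to this amine nitrogen.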